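From Dimethylamino to Hydroxy in Compound 3

The source may hold more compounds than are shown below. What is called first, only, known or untested is meant among the compounds shown, and "the series" means these compounds.

In a functional assay on NCI-H460 cells (Homo sapiens) (on this read-out lower numbers stand for an effect already at smaller amounts and higher numbers for an effect only at larger amounts of compound), compound 3 `COc1cc(C2OC(c3ccc(N(C)C)cc3)=NN2C(=O)CN(C)C)cc(OC)c1OC` stands highest of three numbers at 74 uM against compound 1 `COc1cc(C2OC(c3ccc(N(C)C)cc3)=NN2C=O)cc(OC)c1OC` at 0.12 uM and compound 2 `COc1cc(C2OC(c3ccc(N(C)C)cc3)=NN2C(=O)CN=[N+]=[N-])cc(OC)c1OC` at 0.53 uM on the same core. Compound 4 `COc1cc(C2OC(c3ccc(N(C)C)cc3)=NN2C(=O)CO)cc(OC)c1OC` has not been measured and differs from compound 3 by hydroxy in place of dimethylamino on a saturated chain carbon bound to a carbonyl carbon with hydroxy in place of dimethylamino on a saturated chain carbon bound to a carbonyl carbon. Among the compounds with values here, three measured steps bear on this. Dimethylamino comes with the large 140-fold higher number from compound 2 to compound 3 (2.14 log units; beyond the scatter) and the large 620-fold higher number from compound 1 to compound 3 (2.79 log units; beyond the scatter) while azidomethyl in place of hydrogen gives only the modest 4.4-fold higher number from compound 1 to compound 2 (0.65 log units; beyond the scatter) in the same read-out. Within the data shown here, no hydroxy example exists, but a large step to a lower number is expected. The expected change is a 49-fold lower number from compound 3 to compound 4 (1.69 log units; beyond the scatter) in this assay on this estimate. Compound 4 is estimated at 1.5 uM with a range of 0.25 uM to 10 uM in this read-out.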

Compound 4, concentration for half-maximal effect: 0.043 uM
Compound 4: middle estimate off by 35-fold (1.54 log units), on the high side; measured number below the stated range.
By their numbers in this assay, from the lowest: compound 4; then compound 1; then compound 2; then compound 3.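

In this assay, hydroxy on a saturated chain carbon bound to a carbonyl carbon sits at the opposite end of the series from dimethylamino (a 1700-fold lower number from compound 3 to compound 4 (3.24 log units; beyond the scatter)) and also gives a lower number than azido (a 12-fold lower number from compound 2 to compound 4 (1.09 log units; beyond the scatter)). Azidomethyl and (dimethylamino)methyl had both raised the number over hydrogen on the carbonyl carbon, whereas hydroxymethyl lowers it (a 2.8-fold lower number from compound 1 to compound 4 (0.45 log units; beyond the scatter)), so a substituent here need not cost activity. Nothing available here accounts for the gap between hydroxy and dimethylamino. On these data alone, whether methoxy in place of hydroxy, or a longer chain carrying the hydroxy, keeps the low number remains open. So does whether a primary amine or a carboxylic acid at this carbon follows dimethylamino or hydroxy.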